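Moving the hydroxyl along the piperidine ring

The source may hold more compounds than are shown below. What is called first, only, known or untested is meant among the compounds shown, and "the series" means these compounds.

Compound 1 `Fc1ccccc1Cn1nc(-c2ncc(F)c(N3CCCCC3)n2)cc1-c1ccon1`, compound 2 `OC1CCCN(c2nc(-c3cc(-c4ccon4)n(Cc4ccccc4F)n3)ncc2F)C1` and compound 3 `OC1CCN(c2nc(-c3cc(-c4ccon4)n(Cc4ccccc4F)n3)ncc2F)CC1` share one core and differ only in the group attached to a single aromatic carbon. In an ADME assay on microsomes from liver (Rattus norvegicus) for pharmacokinetics (a lower number here means slower removal, a higher number faster removal of the compound), compound 1 gives 490 uL/min, compound 2 gives 360 uL/min and compound 3 gives 390 uL/min. Compound 3 is closest to compound 2 and furthest from compound 1, yet all three numbers lie within the scatter of each other, as the steps of a 1.4-fold lower number from compound 1 to compound 2 (0.13 log units; within the scatter), a 1.3-fold lower number from compound 1 to compound 3 (0.10 log units; within the scatter) and a 1.1-fold higher number from compound 2 to compound 3 (0.03 log units; within the scatter) show. Compound 4 `OCC1CCCCN1c1nc(-c2cc(-c3ccon3)n(Cc3ccccc3F)n2)ncc1F` carries 2-(hydroxymethyl)piperidin-1-yl in place of 4-hydroxypiperidin-1-yl on an aromatic carbon. Those three small steps are the ones that bear on this change, and they give no reason to expect a step beyond the scatter. For compound 4 the estimated step is a 1.0-fold higher number from compound 3 to compound 4 (0.01 log units; within the scatter). Compound 4 is therefore expected to give 400 uL/min in this assay, within a range from 200 uL/min to 800 uL/min.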

Compound 4, intrinsic clearance in a liver preparation (reported as CLH), per the amount of preparation that the assay uses: 460 uL/min
For compound 4 the middle estimate is 1.2-fold (0.06 log units) below the measured one; the range from low to high includes it.
By their numbers in this assay, from the lowest: compounds 2, 3, 4 and 1 (each within the scatter of the next).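

With 2-(hydroxymethyl)piperidin-1-yl on this aromatic carbon, this assay still shows only small steps, whether set against 4-hydroxypiperidin-1-yl (a 1.2-fold higher number from compound 3 to compound 4 (0.07 log units; within the scatter)), 3-hydroxypiperidin-1-yl (a 1.3-fold higher number from compound 2 to compound 4 (0.11 log units; within the scatter)) or the plain piperidine ring (a 1.1-fold lower number from compound 1 to compound 4 (0.03 log units; within the scatter)). A hydroxymethyl group on the ring therefore behaves here like a hydroxy group, and all four compounds remain within the scatter of one another. Nothing available explains why these numbers stay so close. Still open, going by these compounds, is whether a ring amine or a carboxylic acid on the piperidine, or a morpholine ring in its place, would produce a step beyond the scatter.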